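A few compounds are considered here, and "the series" means these few. Any claim that something is new, unique, unknown or untested is made for them only; others in the source may bear on it.

Among the compounds with values here, in a functional assay (Cavia porcellus) for antagonist activity at Serotonin 3 (5-HT3) receptor (Homo sapiens) (a lower number here means a stronger inhibitor, a higher number a weaker inhibitor), compound 1 `Cc1cccc(N2CCN(C3CN4CCC3CC4)C2=O)c1` gives 12 nM, the lowest of the three numbers measured so far. Compound 2 `O=C1N(c2cc(Cl)cc(Cl)c2)CCN1C1CN2CCC1CC2` gives 45 nM in this assay, and compound 3 `O=C1N(c2ccccc2)CCN1C1CN2CCC1CC2` gives 2100 nM. The step from compound 1 to compound 3 is a single change, hydrogen in place of methyl on an aromatic carbon, and it is large: a 180-fold higher number from compound 1 to compound 3 (2.24 log units; beyond the scatter). Within the data shown here, compound 2 and compound 3 differ in more than one place, so their two values show only that the ring carrying two chlorines gives a far lower number than the bare ring.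

Compound 4 `O=C1N(c2cccc([N+](=O)[O-])c2)CCN1C1CN2CCC1CC2` has not yet been measured. It differs from compound 1 in one place: nitro in place of methyl on an aromatic carbon. Among the measured compounds shown here, the only measured step that bears directly on this change is the one from compound 1 to compound 3, which shows that taking the methyl away costs a great deal. Compound 4 keeps a group on that carbon, but a different one, and nothing measured shows how a nitro behaves there. The expectation is therefore a moderate rise, a 5.0-fold higher number from compound 1 to compound 4 (0.70 log units; beyond the scatter), held with wide uncertainty. Compound 4 is expected to give about 60 nM in this assay, within a range from 10 nM to 400 nM.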

Compound 4, antagonist equilibrium constant: 75.2 nM
The estimate for compound 4 lay 1.3-fold (0.10 log units) below the measured number; measured number inside the range.
By their numbers in this assay, from the lowest: compound 1; then compounds 2 and 4 (each within the scatter of the next); then compound 3.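

In this assay, a nitro on this aromatic carbon gives a 28-fold lower number from compound 3 to compound 4 (1.45 log units; beyond the scatter), so the bare ring, and not only the loss of the methyl, marks the poor case at this position. The earlier compounds shown here could not separate these readings: one step showed that removing the methyl costs a great deal, but not whether a different group could take its place. Two unlike groups, the methyl with 1 heavy atom and the nitro with 3 heavy atoms and 2 hydrogen-bond acceptors, now both give far lower numbers than hydrogen, yet the exchange of one for the other still gives a 6.3-fold higher number from compound 1 to compound 4 (0.80 log units; beyond the scatter) and leaves the methyl ahead, and nothing measured here explains either result.

The compounds shown leave open how an amine, a carboxylic acid or a single chlorine would behave on this carbon, and a single chlorine would also bring compound 2 into a one-place comparison. They also leave open whether a methyl or a nitro on another carbon of the ring would give steps of similar size.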